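A few compounds are considered here, and "the series" means these few. Any claim that something is new, unique, unknown or untested is made for them only; others in the source may bear on it.

In a functional assay on Bel-7402 cells (Homo sapiens) for inhibition, read by MTT assay, with a stated time of 24 h, tested at 1 ug/mL (on this read-out lower numbers stand for less inhibition of growth and higher numbers for more inhibition of growth at the one concentration tested), compound 1 (`CC(=O)SCCC(CCCCC(=O)O)SC(C)=O`) gives 12.8% and compound 2 (`CC(=O)SCCC(CCCCC(=O)Nc1ccccc1Cl)SC(C)=O`) gives 5.01% so these two stand within the scatter of each other. Compound 3 (`CC(=O)SCCC(CCCCC(=O)Nc1cccc(Cl)c1)SC(C)=O`) has 3-chlorophenyl in place of 2-chlorophenyl on an amide-type nitrogen and awaits measurement. Going by the values given here, the single measured step (a number 7.8 percentage points lower from compound 1 to compound 2 (within the scatter)) replaces hydroxy on a carbonyl carbon, and no measured step moves the chlorine. The expected step is a number 3 percentage points higher from compound 2 to compound 3 (within the scatter) and nothing beyond the scatter is expected in either direction in this assay for this change. Compound 3 is estimated at 8% with an expected range of -3% to 20% here.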

Compound 3, percent growth inhibition at one concentration: 0.56%
Compound 3: the middle estimate sits 7.4 percentage points above what was measured; low and high end bracket the measured number.
By their numbers in this assay, from the lowest: compounds 3, 2 and 1 (each within the scatter of the next, the first and the last beyond it).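

In this assay moving the chlorine, with 3-chlorophenyl in place of 2-chlorophenyl on the amide-type nitrogen, gives a number 4.5 percentage points lower from compound 2 to compound 3 (within the scatter) and so does not separate the two chlorophenyl groups. Putting (3-chlorophenyl)amino in place of hydroxy on the carbonyl carbon gives a number 12.2 percentage points lower from compound 1 to compound 3 (beyond the scatter) and so provides a modest step beyond the scatter at this carbon, which (2-chlorophenyl)amino did not. Nothing available bears on the reason for either step.

Open: whether 4-chlorophenyl or plain phenyl on the amide-type nitrogen reads any differently, and whether an alkylamine on the carbonyl carbon matches the chlorophenylamino groups.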